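A Fluorophenyl Swap on a Thiosemicarbazone-Type Series

This account rests on a few compounds, and the source may have more. Where it says the series, first, only, none or still open, it means among the compounds named here.

Compound 1 `COc1ccc(NC(=S)N/N=C\c2ccnc3ccccc23)cc1`: 990 nM
Compound 2 `S=C(N/N=C\c1ccnc2ccccc12)Nc1cccnc1`: 970 nM

In a functional assay on MCF7 cells (Homo sapiens) for cytotoxicity, read by MTT assay, with a stated time of 48 h (a lower number here means a stronger inhibitor, a higher number a weaker inhibitor), compound 2 gives 970 nM and stands within the scatter of compound 1 (at 990 nM), so neither can be ranked above the other. The next compound to be tested is compound 3 `Fc1ccc(NC(=S)N/N=C\c2ccnc3ccccc23)cc1`, which carries 4-fluorophenyl in place of pyridin-3-yl on an amide-type nitrogen and keeps the shared core unchanged.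

Among the compounds with values here, only one measured step bears on this change. It sits at the same place on the amide-type nitrogen and puts pyridin-3-yl in place of 4-methoxyphenyl, and its size is a 1.0-fold lower number from compound 1 to compound 2 (0.01 log units; within the scatter) in this assay. Within the data shown here, that single step stayed within the scatter, though it is thin evidence, and the data hold no measured compound with 4-fluorophenyl. No shift beyond the scatter is therefore expected, in either direction. The expected step in this assay is a 1.0-fold lower number from compound 2 to compound 3 (0.01 log units; within the scatter) by this estimate. For compound 3 the estimated value is 950 nM (expected range 450 nM to 2000 nM).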

Compound 3, half-maximal inhibitory concentration: 1100 nM
For compound 3 the middle estimate is 1.2-fold (0.06 log units) below the measured one, within the range that was stated.
By their numbers in this assay, from the lowest: compounds 2, 1 and 3 (each within the scatter of the next).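

In this assay the swap of pyridin-3-yl for 4-fluorophenyl on the amide-type nitrogen gives a 1.1-fold higher number from compound 2 to compound 3 (0.05 log units; within the scatter) and so shows that a ring of carbon only, without the hydrogen-bond acceptor of pyridin-3-yl, leaves the value within the scatter at this position. The new pair also tests a change on the aryl ring itself, fluoro in place of methoxy on an aromatic carbon, and this gives a 1.1-fold higher number from compound 1 to compound 3 (0.05 log units; within the scatter) in this assay so that the three groups seen at this place cannot be told apart by this read-out. Nothing available explains this flat picture.

All three groups at this place are six-membered aromatic rings, so the compounds shown leave open whether a cyclohexyl ring, a short alkyl chain or a free amine on this nitrogen would stay within the scatter of these values. They also leave open whether a step beyond the scatter would follow from a change elsewhere, such as a carbonyl in place of the thiocarbonyl of the shared core.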